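Ethoxy to Isobutoxy in a Cytotoxicity Series

A few compounds are considered here, and "the series" means these few. Any claim that something is new, unique, unknown or untested is made for them only; others in the source may bear on it.

Of the compounds shown here, three have been measured in a functional assay on HCT-8 cells (Homo sapiens) for cytotoxicity (a lower number here means that less compound is needed, a higher number that more compound is needed for the effect), so far. Compound 1 (`CCOc1cc(-c2ccccc2)nc2ccccc12`) gives > 10 ug/mL as its result, which is a limit of the assay and not a number. Compound 3 (`Oc1cc(-c2ccccc2)nc2c(O)cccc12`) likewise gives only a limit, > 10 ug/mL as printed by the assay. Compound 2 (`Oc1ccc2nc(-c3ccccc3)cc(O)c2c1`) gives a number, 7.75 ug/mL in the same test. Compound 1 therefore stands at the limit of > 10 ug/mL in this assay, at which 2 of the 3 values shown sit, and has no exact position.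

Compound 4 (`CC(C)COc1cc(-c2ccccc2)nc2ccccc12`) carries isopropyl in place of methyl on a saturated chain carbon bound to an oxygen on an aromatic ring, so that ethoxy becomes isobutoxy (isopropyl in place of methyl on a saturated chain carbon bound to an oxygen on an aromatic ring). Within the data shown here, no measured step speaks to this change, so the expectation rests on compound 1 and its limit of > 10 ug/mL alone. The expected change in this assay is a step that the limit leaves unreadable from compound 1 to compound 4 and it is not expected to go beyond the usual scatter in either direction. For compound 4 the estimate is 12 ug/mL with an expected range of 6 ug/mL to 25 ug/mL and an outcome that is only a limit is quite likely.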

Compound 4, half-maximal effective concentration: > 10 ug/mL
Compound 4: only a limit was reported; the forecaster's own chance of this, stated with the estimate: 65%; the middle value lies beyond the limit too.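

In this assay compound 4 gives > 10 ug/mL as a limit of the assay and not a number. Compound 1 also stands at a limit, so no step can be read between compound 1 and compound 4. The compounds shown leave open whether ethoxy and isobutoxy differ at all in this read-out, as both compounds stand at the same limit: the limit of > 10 ug/mL in this assay, at which 3 of the 4 values shown sit.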